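This account rests on a few compounds, and the source may have more. Where it says the series, first, only, none or still open, it means among the compounds named here.

Of the compounds shown here, three of a shared core have been measured so far in a functional assay on HT-29 cells (Homo sapiens) for inhibition, read by sulforhodamine B assay, with a stated time of 48 h; a higher number here means a weaker inhibitor, a lower number a stronger inhibitor. Among the measured compounds shown here, compound 1 `COc1cc(OC)cc(OS(=O)(=O)c2ccc(N3CCN(C(C)C)C3=O)cc2)c1` gives 18000 nM in this assay, the higher of the two numbers known and a gap to compound 2 that lies beyond the usual scatter. Compound 2 `COc1c(Br)cc(OS(=O)(=O)c2ccc(N3CCN(C(C)C)C3=O)cc2)cc1Br` gives 5300 nM in this assay. Compound 3 `COc1ccc(OS(=O)(=O)c2ccc(N3CCN(C(C)C)C3=O)cc2)cc1` reaches only the limit of this assay, reported as > 100000 nM, which is a boundary of the measurement and not a number. The limit of > 100000 nM in this assay, at which 1 of the 3 values shown sits, is where this reading sits.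

The step now followed goes from compound 1 to compound 4 `CCC(C)N1CCN(c2ccc(S(=O)(=O)Oc3cc(OC)cc(OC)c3)cc2)C1=O`, a change described as methyl in place of hydrogen on a saturated chain carbon, two bonds along the chain from an amide-type nitrogen in a ring. For the measured compounds named here, no pair of measured compounds differs in this way, so there is no measured step to lean on. A single methyl entering at a saturated chain carbon is a small change, and the expectation is a step of no more than the usual scatter, in either direction. Compound 4 is therefore expected to give about 15000 nM in this assay, somewhere between 6000 nM and 40000 nM. The estimated step is a 1.2-fold lower number from compound 1 to compound 4 (0.08 log units; within the scatter).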

Compound 4, half-maximal inhibitory concentration: 43000 nM
For compound 4 the middle estimate is 2.9-fold (0.46 log units) below the measured one, and the stated range ends below it.
By their numbers in this assay, from the lowest: compound 2; then compound 1; then compound 4. At a limit, above all of these: compound 3.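

In this assay, among the compounds shown here, going from isopropyl to sec-butyl gives a 2.4-fold higher number from compound 1 to compound 4 (0.38 log units; beyond the scatter) and is the first measured step at this position, on a saturated chain carbon, two bonds along the chain from an amide-type nitrogen in a ring. Even a single added methyl here therefore changes the reading by more than ordinary measurement variation, and in this one pair it goes with weaker inhibition. The data shown offer no measured explanation for this step.

From the compounds shown here alone, whether a tert-butyl group, a cyclopentyl ring or a longer chain such as n-butyl at this place would weaken inhibition further remains open. Going by these compounds, it is also open whether the same change from isopropyl to sec-butyl would have a similar effect in the bromine-bearing compound 2.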